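Swapping a methoxymethoxy for a methoxy on compound 2

A few compounds are considered here, and "the series" means these few. Any claim that something is new, unique, unknown or untested is made for them only; others in the source may bear on it.

Compound 1 `COCOc1cc(OC)cc(OC)c1C(=O)/C=C/c1ccccc1` gives 4800 nM
Compound 2 `COCOc1cc(OCOC)c(C(=O)/C=C/c2ccccc2)c(OCOC)c1` gives 11500 nM

In a functional assay on HeLa cells (Homo sapiens) for cytotoxicity, read by resazurin assay, with a stated time of 72 h (a lower number here means a stronger inhibitor, a higher number a weaker inhibitor), compound 2 stands at 11500 nM, the higher of the two numbers, and its gap to compound 1 at 4800 nM lies beyond the scatter. Compound 3 `COCOc1cc(OC)c(C(=O)/C=C/c2ccccc2)c(OCOC)c1` comes from compound 2 by a single change, hydrogen in place of methoxy on a saturated chain carbon bound to an oxygen on an aromatic ring, turning one methoxymethoxy into a methoxy. Among the measured compounds shown here, no measured pair isolates this change, so the two values are the only guide. Compound 1, which also carries methoxy groups, reads 4800 nM, so a small fall in the number is expected, near the edge of the scatter. The expected move is a 1.5-fold lower number from compound 2 to compound 3 (0.19 log units; within the scatter). For compound 3 the estimated value is 7500 nM, with an expected range of 3500 nM to 13000 nM.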

Compound 3, half-maximal inhibitory concentration: 9700 nM
Compound 3: the middle estimate sits 1.3-fold (0.11 log units) below what was measured; measured number inside the range.
By their numbers in this assay, from the lowest: compound 1; then compounds 3 and 2 (each within the scatter of the next).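

In this assay, turning one methoxymethoxy into a methoxy gives a 1.2-fold lower number from compound 2 to compound 3 (0.07 log units; within the scatter) and so, taken alone at this position, stays inside the scatter. The same kind of change with one methoxy already in place on the shared core, read in the direction listed, gives a 2.0-fold higher number from compound 1 to compound 3 (0.31 log units; beyond the scatter) and this modest step lies beyond the scatter. The two steps therefore do not read alike against the scatter, and nothing measured here offers a reason for either of them. The compounds shown leave open whether another group on this oxygen-bearing position of the ring, such as a free hydroxyl, a longer alkoxy chain or an amine, would shift the number further. They also leave open whether these steps would hold on any other cell line.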